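Adding chloro to compound 2

The compounds below may be only part of what the source reports. "The series", "measured", "known", "first", "only" and "open" are said of these compounds alone.

Compound 1 `[O-][n+]1nc(NC2CCCC2)[n+]([O-])c2ccccc21`: 10 ug/mL
Compound 2 `[O-][n+]1nc(NC2CCCCC2)[n+]([O-])c2ccccc21`: 8.9 ug/mL
Compound 3 `CCCC(C)Nc1n[n+]([O-])c2ccccc2[n+]1[O-]`: 26 ug/mL

In an ADME assay on Vero cells (Chlorocebus sabaeus) for cytotoxicity, read by CellTiter-Glo, with a stated time of 72 h (a lower number here means that less compound is tolerated, a higher number that more compound is tolerated), compound 2 gives 8.9 ug/mL, at the low end of these numbers and level with compound 1 within the scatter. Cyclohexyl in place of cyclopentyl gave a 1.1-fold lower number from compound 1 to compound 2 (0.05 log units; within the scatter). The 1-methylbutyl group gave a 2.6-fold higher number from compound 1 to compound 3 (0.41 log units; beyond the scatter) and a 2.9-fold higher number from compound 2 to compound 3 (0.47 log units; beyond the scatter). Compound 4 `[O-][n+]1nc(NC2CCCCC2)[n+]([O-])c2ccc(Cl)cc21` keeps the cyclohexyl group and changes the shared core instead: chloro in place of hydrogen on an aromatic carbon. Every measured step changes only the group on nitrogen, so none tests this change directly. No step beyond the scatter is expected, and the estimate is a 1.2-fold lower number from compound 2 to compound 4 (0.07 log units; within the scatter). Compound 4 is expected at 7.5 ug/mL, with an estimated range from 3.5 ug/mL to 16 ug/mL.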

Compound 4, half-maximal cytotoxic concentration: 2.6 ug/mL
Beside the measured number, compound 4's estimate is 2.9-fold (0.46 log units) above it; measured number outside the range, below it.
By their numbers in this assay, from the lowest: compound 4; then compounds 2 and 1 (each within the scatter of the next); then compound 3.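

In this assay, chloro in place of hydrogen on an aromatic carbon gave a 3.4-fold lower number from compound 2 to compound 4 (0.53 log units; beyond the scatter), a step beyond the scatter. The earlier compounds shown here varied only the group on nitrogen, whereas this result shows that a change to the shared core can also alter how much compound the cells tolerate. Nothing measured here gives a reason for this step. Still open, going by these compounds, is whether a fluoro or methoxy group on this carbon would act like chloro, and whether chloro would give a similar step with cyclopentyl or 1-methylbutyl on nitrogen.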